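A few compounds are considered here, and "the series" means these few. Any claim that something is new, unique, unknown or untested is made for them only; others in the source may bear on it.

Working notes on the series.

Of the compounds shown here, three have been measured in a functional assay on the whole organism (blood) with Rattus norvegicus as the target, at a dose of 100 mg/kg by the oral route; a lower number here means less inhibition, a higher number more inhibition at the dose given (going by the name of the read-out). Compound 1 `N#Cc1ccc(OCC(O)CN2CCN(c3ccc(F)cc3)CC2)cc1` gives 38.6%. Compound 2 `N#Cc1ccc(OCC(O)CN2CCN(c3cccc(Cl)c3)CC2)cc1` gives 16.5%. Compound 3 `COc1ccc(N2CCN(CC(O)COc3ccc(Cl)cc3)CC2)cc1` gives 4.6%, the lowest of the three numbers; it sits beyond the scatter below compound 2 and further still below compound 1.

Within the data shown here, the only single-site step measured so far is a number 22.1 percentage points lower from compound 1 to compound 2 (beyond the scatter), which moved the read-out modestly downward. Among the measured compounds shown here, it is the one change on the same amine nitrogen in the ring and is therefore the nearest guide for compound 4 `OC(COc1ccc(Cl)cc1)CN1CCN(c2ccc(Cl)c(Cl)c2)CC1`, although it compares two different aryl groups.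

Compound 4 differs from compound 3 as follows: 3,4-dichlorophenyl in place of 4-methoxyphenyl on an amine nitrogen in a ring. For the measured compounds named here, with only one relevant step on record, and that step pointing downward from a different starting group, there is little basis for expecting a large rise; at the same time compound 3 is already near the floor of the read-out, so a large fall is not possible. The step from compound 3 to compound 4 in this assay is therefore expected to be small, likely within the scatter: a number 5.4 percentage points higher from compound 3 to compound 4 (within the scatter).

For compound 4 the estimate in this assay is 10%, ranging from 0% to 28%.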

Compound 4, a percentage reported as inhibition, in the whole organism at one dose (the size of the read-out at that dose, not a potency): 3.52%
For compound 4 the middle estimate is 6.5 percentage points above the measured one; the measured number falls inside the stated range.
By their numbers in this assay, from the lowest: compounds 4 and 3 (each within the scatter of the next); then compound 2; then compound 1.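

In this assay the exchange of 4-methoxyphenyl for 3,4-dichlorophenyl on an amine nitrogen in a ring amounts to a number 1.1 percentage points lower from compound 3 to compound 4 (within the scatter) and thus leaves these two aryl groups unresolved by this read-out at this dose on the core of compound 3. The earlier step on the same nitrogen, a number 22.1 percentage points lower from compound 1 to compound 2 (beyond the scatter) on a different core and with different aryl groups, lay beyond the scatter, so this position does not separate every pair of aryl groups, although two steps that differ in core and in groups cannot be read as one trend. No measurement is available that explains why this pair stays unresolved.

Open, on these data alone, is whether the 4-fluorophenyl group of compound 1 would raise the read-out on the core of compound 3, which would show whether that group or the rest of the core goes with the higher number. Also open, as far as these compounds go, is how an unsubstituted phenyl or a 2-pyridyl group on the same nitrogen would read on either core.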